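The source may hold more compounds than are shown below. What is called first, only, known or untested is meant among the compounds shown, and "the series" means these compounds.

Three compounds share one core, and the question is how one change at the five-membered ring of that core bears on exposure after oral dosing. Compound 1 `CCOc1cc(C(=O)N(C)C)ccc1Nc1nc(O[C@H]2CC[C@@](C)(O)CC2)c2cc[nH]c2n1` carries an ethoxy group on the aniline ring; in an ADME assay on the whole organism (Rattus norvegicus) for pharmacokinetics, at a dose of 10 mg/kg by the oral route (a lower number here means less compound in the circulation, a higher number more compound in the circulation at the dose given), compound 1 is recorded as "not determined" (no result reported), so it gives no number to lean on. For the measured compounds named here, compound 2 `C[C@@H](Oc1cc(C(=O)N(C)C)ccc1Nc1nc(O[C@H]2CC[C@@](C)(O)CC2)c2c(Cl)c[nH]c2n1)C(F)(F)F`, which bears a trifluoromethyl-substituted ether and a chloro on the fused ring, is the one measured compound: in this assay compound 2 gives 14500 ng.h/mL, the only number in hand, so it stands alone and cannot be ranked against anything. Compound 3 `C[C@@H](Oc1cc(C(=O)N(C)C)ccc1Nc1nc(O[C@H]2CC[C@@](C)(O)CC2)c2cc[nH]c2n1)C(F)(F)F` differs from compound 2 in one place (hydrogen in place of chloro on an aromatic carbon). Going by the values given here, no step between two measured compounds is available, so the size of this one is a guess. The expectation is a step from compound 2 to compound 3 of a 1.5-fold lower number from compound 2 to compound 3 (0.16 log units; within the scatter), not clearly beyond the usual scatter. Compound 3 is therefore estimated at 10000 ng.h/mL, with a range from 4000 ng.h/mL to 25000 ng.h/mL.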

Compound 3, area under the concentration-time curve: 15600 ng.h/mL
Compound 3: the middle estimate sits 1.6-fold (0.19 log units) below what was measured; low and high end bracket the measured number.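

In this assay, for the compounds shown here, the exchange of chloro for hydrogen on the aromatic carbon of the five-membered ring is a 1.1-fold higher number from compound 2 to compound 3 (0.03 log units; within the scatter) and so gives the first readable step in this set. The two numbers cannot be told apart, so with the trifluoromethyl-substituted ether in place, this position carries either chloro or hydrogen with oral exposure in the same range. Nothing at hand bears on why the two compounds read alike.

On these data alone, compound 1 has no number, so the steps that involve its ethoxy group cannot be read, and whether that ether matters for exposure stays open. Also open, as far as these compounds go, is whether a group such as a nitrile, a methyl or an amine on this same carbon would stay in that range, since chloro and hydrogen are the only two seen here.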